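The source may report more compounds than this note shows. Statements on the series, on what has been measured and on what is new or still open speak of the compounds shown alone.

Working notes on the series.

Three compounds have been run in a functional assay on the whole organism (strain albino) for inhibition, with Rattus norvegicus as the target, read by paw edema, with stated times of 30 min and 4 h, at a dose of 0.28 mmol/kg by the oral route; on this read-out higher numbers stand for more inhibition at the one dose given (going by the name of the read-out) and lower numbers for less inhibition. Compound 1 `COc1cc(-c2nnc(SCC(=O)Nc3ccc(/C(C)=N/O)cc3)n2-c2ccccc2)cc(OC)c1OC` gives 75% in this assay. Compound 3 `COc1ccc(-c2nnc(SCC(=O)Nc3ccc(/C(C)=N/O)cc3)n2-c2ccccc2)cc1OC` gives 79%. Compound 2 `CCn1c(SCC(=O)Nc2ccc(C(C)=O)cc2)nnc1-c1ccc(OC)c(OC)c1` gives 69%. The change from compound 1 to compound 3 is hydrogen in place of methoxy on an aromatic carbon, and the step it made was a number 4 percentage points higher from compound 1 to compound 3 (within the scatter). Compound 2 against compound 1 and against compound 3 lies within the usual scatter on both comparisons, so no order among the three can be read from these numbers. The difference between the core of compound 2 and the core of compound 1 is not broken down here.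

Compound 4 `CCn1c(SCC(=O)Nc2ccc(C(C)=O)cc2)nnc1-c1ccc(OC)cc1` is not yet measured. It differs from compound 2 by hydrogen in place of methoxy on an aromatic carbon. Going by the values given here, this is the same kind of change as the one from compound 1 to compound 3, but not the same: around the place in compound 1 the leaving methoxy was also meta to a methoxy group, whereas around the place in compound 2 it is ortho to a methoxy group and meta to a large group only. The change appears in two pairs in this set, one measured and one not.

For compound 4 in this assay the step from compound 2 is expected to be a number 1 percentage points higher from compound 2 to compound 4 (within the scatter), resting on the step of a number 4 percentage points higher from compound 1 to compound 3 (within the scatter), which stayed within the scatter. On that basis compound 4 is estimated to give 70%, with the expected range running from 58% to 80%.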

Compound 4, a percentage reported as inhibition, in the whole organism at one dose (the size of the read-out at that dose, not a potency): 65%
Estimate against measurement, compound 4: 5 percentage points above; measured number inside the range.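

In this assay, hydrogen in place of methoxy on an aromatic carbon, here 3,4-dimethoxyphenyl to 4-methoxyphenyl, gives a number 4 percentage points lower from compound 2 to compound 4 (within the scatter). Set beside the earlier step, the new one shows no difference between the two cores: the same change on two cores in this assay, a number 4 percentage points higher (within the scatter) from compound 1 to compound 3 and a number 4 percentage points lower (within the scatter) from compound 2 to compound 4, 8 percentage points apart, within the scatter of two such steps So far, the change carries from one core to the other only in the limited sense that it stays within the scatter on both; this does not show that it has no effect, that its effect is the same on both cores, or that the opposite signs of the two steps mean anything, and the surroundings of the leaving methoxy are not the same in the two pairs.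

The compounds shown leave open whether a group other than hydrogen in that place, such as a chlorine atom, a hydroxyl or an amine, would take the number beyond the scatter on either core. Going by these compounds alone, they also leave open how much the ethyl group and the phenyl group on the cores, or the ketone and the oxime, each contribute, as no pair here differs in only one of these places.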